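The compounds below may be only part of what the source reports. "The series", "measured", "known", "first", "only" and "open" are said of these compounds alone.

The measured compounds:
compound 1, `Cc1ccc2cc(-c3nn[nH]n3)cnc2c1C`, 25 mg/kg
compound 2, `c1ccc2ncc(-c3nn[nH]n3)cc2c1`, 25 mg/kg

Both were tested in a functional assay on the whole organism (strain Sprague-Dawley) for inhibition, with Rattus norvegicus as the target; on this read-out lower numbers stand for an effect already at smaller amounts and higher numbers for an effect only at larger amounts of compound. Compound 1 gives 25 mg/kg there and compound 2 gives 25 mg/kg; at the digits reported compound 2 stands level with compound 1, its nearest neighbour, and the two values lie within the scatter of the method. Compound 3, `Cc1cccc2cc(-c3nn[nH]n3)cnc12`, has not yet been measured in this assay. It differs from compound 2 by a single change: methyl in place of hydrogen on an aromatic carbon. Going by the values given here, no pair of measured compounds differs in only one place, so no directly comparable step is on record. Compound 1 carries methyl groups on the shared core and gives 25 mg/kg; compound 2 lacks them and gives 25 mg/kg. On that showing a single methyl is not expected to move the read-out beyond the scatter. The step of no change at the digits printed from compound 2 to compound 3 (within the scatter) is expected to be essentially none. Compound 3 is estimated at 25 mg/kg, within a range of 12 mg/kg to 50 mg/kg.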

Compound 3, minimum effective dose: 25 mg/kg
For compound 3 middle estimate and measured number coincide at the digits printed; the range from low to high includes it.
By their numbers in this assay, from the lowest: compounds 1, 2 and 3 (each within the scatter of the next).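

The methyl on an aromatic carbon of the six-membered aromatic ring of carbon only, ortho to a fused ring, now stands on record as a single change, and in this assay it gives no change at the digits printed from compound 2 to compound 3 (within the scatter). The other single change, hydrogen in place of methyl on an aromatic carbon, reads the same way, with no change at the digits printed from compound 1 to compound 3 (within the scatter), so both one-place steps among these compounds lie within the scatter rather than only the two-methyl contrast seen earlier. No measurement at hand offers an explanation for this flat result.

What the compounds leave open is whether this carbon accepts only a small group such as methyl, or whether a methoxy group, an amine or a carboxylic acid there would move the read-out. Since all three values coincide, they also do not show which part of the shared core the read-out depends on.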